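Phenyl in place of benzyloxy in a cytotoxicity series

A few compounds are considered here, and "the series" means these few. Any claim that something is new, unique, unknown or untested is made for them only; others in the source may bear on it.

Compound 1 `C=C[C@@](C)(/C=C/c1ccc(OCc2ccccc2)cc1)CCC=C(C)C` stands at the ceiling of a functional assay on SEM cells (Homo sapiens) for cytotoxicity, with a stated time of 72 h; on this read-out lower numbers stand for an effect already at smaller amounts and higher numbers for an effect only at larger amounts of compound: in this assay compound 1 gives > 36600 nM, which is a limit rather than a number. Compound 2 `C=C[C@@](C)(/C=C/c1ccc(Nc2cc(F)c(F)cc2F)cc1)CCC=C(C)C` likewise returns only a limit in this assay, > 36600 nM. Among the measured compounds shown here, both values sit at the same ceiling (the limit of > 36600 nM in this assay, at which 2 of the 2 values shown sit), so no measured step can be placed between them. Compound 3 `C=C[C@@](C)(/C=C/c1ccc(-c2ccccc2)cc1)CCC=C(C)C` carries phenyl in place of benzyloxy on an aromatic carbon. No change beyond the scatter is expected, so the step that the limit leaves unreadable from compound 1 to compound 3 is set close to nothing. Compound 3 is estimated at 40000 nM in this assay, with a range from 15000 nM to 100000 nM, and most likely again only a limit will be reported.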

Compound 3, half-maximal effective concentration: > 36600 nM
Compound 3 gave a limit, no number; the forecaster's own chance of this, stated with the estimate: 85%; the middle value is on the limit's open side.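

Compound 1 and compound 3 yield no readable step in this assay, as each gives only a limit: the limit of > 36600 nM in this assay, at which 3 of the 3 values shown sit.

The compounds shown leave open at what concentration, if any, this series produces a measurable effect in this assay.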